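The source may report more compounds than this note shows. Statements on the series, on what has been measured and on what is new or still open speak of the compounds shown alone.

Values in a functional assay on HCT-116 cells (Homo sapiens) for inhibition, read by MTT assay, with a stated time of 72 h; a higher number here means a weaker inhibitor, a lower number a stronger inhibitor:
- Compound 1 `Cc1cc(C)cc(CN2CCc3ncn(COCc4ccccc4)c3/C(=C/c3ccccc3)C2=O)c1`: 6230 nM
- Compound 2 `Cc1cccc(CN2CCc3ncn(COCc4ccccc4)c3/C(=C/c3ccccc3)C2=O)c1`: 3800 nM

Among the compounds with values here, only these two compounds have numbers so far, so compound 2 has a single neighbour, and the two cannot be told apart: a 1.6-fold lower number from compound 1 to compound 2 (0.21 log units; within the scatter). The next compound, compound 3 `O=C1/C(=C\c2ccccc2)c2c(ncn2COCc2ccccc2)CCN1Cc1ccc(-c2ccccc2)cc1`, keeps the shared core and changes the group on a saturated chain carbon bound to an amide-type nitrogen in a ring: 4-phenylphenyl in place of 3-methylphenyl on a saturated chain carbon bound to an amide-type nitrogen in a ring. Within the data shown here, this is a far bigger structural edit than the one measured step, where hydrogen replaces methyl on an aromatic carbon. Among the measured compounds shown here, that step, a 1.6-fold lower number from compound 1 to compound 2 (0.21 log units; within the scatter), therefore offers little guidance, and no measured compound carries 4-phenylphenyl. The data point in neither direction, so the best guess is no shift beyond the scatter, with a wide margin on both sides. The expected change is a 1.3-fold lower number from compound 2 to compound 3 (0.10 log units; within the scatter). For compound 3 the estimated value in this assay is 3000 nM, with an expected range from 800 nM to 11000 nM.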

Compound 3, half-maximal inhibitory concentration: 14000 nM
Beside the measured number, compound 3's estimate is 4.7-fold (0.67 log units) below it; the whole stated range lies below it.
By their numbers in this assay, from the lowest: compounds 2 and 1 (each within the scatter of the next); then compound 3.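

At the place on a saturated chain carbon bound to an amide-type nitrogen in a ring, the group now makes a readable difference in this assay. Putting 4-phenylphenyl in place of 3-methylphenyl gives a 3.7-fold higher number from compound 2 to compound 3 (0.57 log units; beyond the scatter) and putting it in place of 3,5-dimethylphenyl gives a 2.2-fold higher number from compound 1 to compound 3 (0.35 log units; beyond the scatter), so both modest steps run toward weaker inhibition, whereas removing one methyl from the aromatic ring had stayed within the scatter. No accompanying measurement accounts for this shift.

With one biphenyl-type group at this place, the data cannot separate the effect of adding the second aromatic ring from the effect of moving the substituent on the first ring. As far as these compounds go, it also remains open how this assay would read a ring carrying an amine or a carboxylic acid here, or a pyridine ring in place of the carbon-only ring.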